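Putting 1,3-thiazol-2-yl on the amide-type nitrogen

A few compounds are considered here, and "the series" means these few. Any claim that something is new, unique, unknown or untested is made for them only; others in the source may bear on it.

Three amides sharing one core have been tested so far: compound 1 `CCNC(=O)CCc1cccc2c1B(O)OC2`, compound 2 `O=C(CCc1cccc2c1B(O)OC2)Nc1ccccc1` and compound 3 `O=C(CCc1cccc2c1B(O)OC2)NCc1ccccc1`. In a functional assay on MDA-MB-231 cells (Homo sapiens) for antiproliferative activity, read by MTT assay, with a stated time of 72 h (on this read-out higher numbers stand for weaker inhibition and lower numbers for stronger inhibition), compound 3 gives > 100000 nM, which is a limit and not a number. Compound 1 also gives only a limit, > 100000 nM. Compound 2 gives a real number, 230 nM.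

Compound 4 `O=C(CCc1cccc2c1B(O)OC2)Nc1nccs1` has not yet been measured. Its difference from compound 3 is 1,3-thiazol-2-yl in place of benzyl on an amide-type nitrogen. Within the data shown here, two measured steps bear on this change. One is an at least 430-fold lower number from compound 1 to compound 2 (2.63 log units; beyond the scatter), and the other is an at least 430-fold higher number from compound 2 to compound 3 (2.63 log units; beyond the scatter). Both are large, and both set compound 2, with phenyl on that nitrogen, apart from the other two. Compound 4 likewise carries an aromatic ring on that nitrogen, so it is expected to resemble compound 2 at 230 nM, though less closely than a direct match. A large move to a lower number is therefore expected, namely an at least 100-fold lower number from compound 3 to compound 4 (2.00 log units; beyond the scatter). For compound 4 the estimate is 1000 nM, with an expected range of 150 nM to 20000 nM.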

Compound 4, half-maximal inhibitory concentration: > 100000 nM
Compound 4 was reported as a limit (the forecaster's own chance of this, stated with the estimate: 20%); middle value at least 100-fold (2.00 log units) from the limit.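

In this assay, 1,3-thiazol-2-yl in place of phenyl on the amide-type nitrogen gives an at least 430-fold higher number from compound 2 to compound 4 (2.63 log units; beyond the scatter), so an aromatic ring directly on that nitrogen is not enough on its own to keep the activity of compound 2. Among these four amides, only phenyl gives a real number, while ethyl, benzyl and 1,3-thiazol-2-yl all end at the same limit of the assay: the limit of > 100000 nM in this assay, at which 3 of the 4 values shown sit. Compound 1, compound 3 and compound 4 all sit at this limit, and the steps among them cannot be read.

The compounds shown leave open whether a six-membered ring with a ring nitrogen, such as pyridin-2-yl, would behave like phenyl or like 1,3-thiazol-2-yl. They also leave open whether a phenyl ring carrying a chlorine atom or a methoxy group would keep the value of compound 2.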